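The source may report more compounds than this note shows. Statements on the series, on what has been measured and on what is new or still open speak of the compounds shown alone.

Measured compounds:
- compound 1 `O=C(O)Cc1sc(Nc2ccccc2)nc1-c1ccccc1`
- compound 2 `O=C(O)Cc1sc(Nc2ccccc2)nc1-c1ccc(F)cc1`
- compound 3 `COc1ccccc1Nc1nc(-c2ccc(F)cc2)c(CC(=O)O)s1`

In an in vitro functional assay on HEK285-7 cells for antagonist activity at prostaglandin D2 receptor 2 (Homo sapiens), read by BRET and beta-arrestin recruitment (a higher number here means a larger maximal response, a lower number a smaller maximal response), compound 1 gives > 70%, which is a limit of the assay. Compound 2 gives > 70%, also a limit. Compound 3 gives > 70%, again a limit. All three therefore sit at the limit of > 70% in this assay, at which 3 of the 3 values shown sit, and the steps a step that the two limits leave unreadable from compound 1 to compound 2 and a step that the two limits leave unreadable from compound 2 to compound 3 cannot be sized.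

Compound 4 `COc1ccc(Nc2nc(-c3ccccc3)c(CC(=O)O)s2)cc1` is not yet measured. It differs from compound 1 by methoxy in place of hydrogen on an aromatic carbon. The same kind of change, though not the same, separates compound 2 and compound 3: methoxy in place of hydrogen on an aromatic carbon, where the methoxy stands ortho to a large group rather than para to a large group. The two cores differ by hydrogen in place of fluoro on an aromatic carbon.

Given that every measured value rests at the limit, the step that the limit leaves unreadable from compound 1 to compound 4 is expected to be small, and compound 4 is estimated at 80%, most likely reported again as a limit.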

Compound 4, largest response reached (reported as efficacy), in percent of the reference or control that the assay uses: > 70%
Compound 4: no number, only a limit; the forecaster's own chance of this, stated with the estimate: 80%; the middle value does not contradict the limit.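

No step can be read from compound 1 to compound 4, because both values are limits: the limit of > 70% in this assay, at which 4 of the 4 values shown sit.

The compounds shown leave open the actual maximal response of each in this assay, and whether methoxy in place of hydrogen shifts it at all.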